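A few compounds are considered here, and "the series" means these few. Any claim that something is new, unique, unknown or untested is made for them only; others in the source may bear on it.

In a functional assay on SW480 cells (Homo sapiens) for antiproliferative activity, read by sulforhodamine B assay, with a stated time of 48 h (a lower number here means a stronger inhibitor, a higher number a weaker inhibitor), three compounds sharing one core have been measured. Compound 1 (`COc1ccc(/C=C/C(=O)c2ccccc2-c2ccc(OC)c(OC)c2)cc1`) gives 890 nM, compound 2 (`COc1ccc(/C=C/C(=O)c2ccccc2-c2ccc(OC)c(OC)c2)cc1OC`) gives 7600 nM, and compound 3 (`COc1ccc(/C=C/C(=O)c2ccccc2-c2ccc(F)cc2)cc1`) gives 61 nM, the lowest number of the three and well clear of the other two. Compound 4 (`COc1ccc(/C=C/C(=O)c2ccccc2-c2ccc(F)cc2)cc1B(O)O`) departs from compound 3 by one change, (a group of 3 heavy atoms (1 boron, 2 oxygen; no ring) in place of a hydrogen atom, on an aromatic carbon), on an aromatic carbon of a six-membered aromatic ring of carbon only, ortho to a methoxy group and meta to a large group. Among the measured compounds shown here, the one measured step that bears on this is an 8.5-fold higher number from compound 1 to compound 2 (0.93 log units; beyond the scatter), which also puts a new group on an aromatic carbon ortho to a methoxy group. For the measured compounds named here, that new group is only a methoxy, however, and no measured compound carries the group entering here, so this single step is a loose guide. The estimated step is therefore somewhat smaller but in the same direction, a 3.0-fold higher number from compound 3 to compound 4 (0.47 log units; beyond the scatter). Compound 4 is expected at about 180 nM, with an estimated range of 30 nM to 1000 nM.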

Compound 4, half-maximal inhibitory concentration: 41 nM
Estimate against measurement, compound 4: 4.4-fold (0.64 log units) above; low and high end bracket the measured number.
By their numbers in this assay, from the lowest: compounds 4 and 3 (each within the scatter of the next); then compound 1; then compound 2.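

In this assay, putting a group of 3 heavy atoms (1 boron, 2 oxygen; no ring) on this aromatic carbon, ortho to a methoxy group, is a step of a 1.5-fold lower number from compound 3 to compound 4 (0.17 log units; within the scatter), so this position accepts the group without a change that can be told from the scatter. The only earlier substitution ortho to a methoxy group, a step of an 8.5-fold higher number from compound 1 to compound 2 (0.93 log units; beyond the scatter), put a methoxy on a parent that differs from compound 3 elsewhere, so a higher number is not the outcome for every group placed ortho to a methoxy group. No measurement shown here accounts for the difference between these two steps.

From the compounds shown here alone, it remains open how an amine, a carboxylic acid or a hydroxyl would fare at this carbon. Also open, going by these compounds, is whether the boron-bearing group would behave the same way on compound 1 .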